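The source may report more compounds than this note shows. Statements on the series, on what has been measured and on what is new or still open speak of the compounds shown alone.

Going by the values given here, compound 1 `COc1cc(NC(C)CCCNC(=O)NNC(=O)Nc2ccc(C(F)(F)F)cc2)c2ncccc2c1` is one of two compounds measured in a functional assay on MOLT-4 cells (Homo sapiens) for inhibition, read by MTT assay, with a stated time of 72 h (a higher number here means a weaker inhibitor, a lower number a stronger inhibitor), so far, and it stands with the higher of the two numbers: compound 1 gives 24000 nM. Among the compounds with values here, its only companion is compound 2 `COc1cc(NC(C)CCCNC(=O)NNC(=O)Nc2cc(C(F)(F)F)cc(C(F)(F)F)c2)c2ncccc2c1`, which in this assay gives 22000 nM; the two numbers lie within the scatter of each other, so nothing can be made of their order. Within the data shown here, no step between measured compounds is available to guide a prediction.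

The step under consideration leads to compound 3 `COc1cc(NC(C)CCCNC(=O)NNC(=O)Nc2ccc(O)cc2)c2ncccc2c1`. The change from compound 1 is hydroxy in place of trifluoromethyl on an aromatic carbon. Both measured compounds carry a trifluoromethyl-bearing ring at this end of the molecule, and neither tells how a hydroxy there would fare. The expectation for compound 3 is therefore a step of a 1.3-fold higher number from compound 1 to compound 3 (0.10 log units; within the scatter), no larger than the scatter and in no firm direction. Compound 3 is estimated at 30000 nM, within a range from 10000 nM to 90000 nM.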

Compound 3, half-maximal inhibitory concentration: 104000 nM
For compound 3 the middle estimate is 3.5-fold (0.54 log units) below the measured one; measured number outside the range, above it.
By their numbers in this assay, from the lowest: compounds 2 and 1 (each within the scatter of the next); then compound 3.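

In this assay, the aromatic carbon para to a large group proves not to be indifferent to what it carries: hydroxy in place of trifluoromethyl gives a 4.3-fold higher number from compound 1 to compound 3 (0.64 log units; beyond the scatter), a modest step but one beyond the scatter. Going by these compounds alone, the earlier compounds both carried trifluoromethyl on this ring, so this pair is the first to show that exchanging the group there can weaken inhibition in these cells. Nothing at hand accounts for the size or the direction of this step.

The compounds shown leave open whether the rise goes with the arrival of hydroxy or with the departure of trifluoromethyl, and a single pair cannot separate the two. On these data alone, how a methoxy group, an amine or a bare hydrogen on that same carbon would read in this assay also remains open.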